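The compounds below may be only part of what the source reports. "The series", "measured", "known", "first", "only" and "open" are said of these compounds alone.

Compounds measured so far:
- compound 1 `CCCOC(=O)C1=C(C)NC(=O)NC1c1cccs1` gives 32% in an assay on membranes from HeLa cells for displacement of a labelled ligand from adenosine receptor A3 (Homo sapiens), read by scintillation counting, with a stated time of 180 min, tested at 1 uM; a lower number here means less inhibition, a higher number more inhibition at the concentration tested (going by the name of the read-out)
- compound 2 `CCCOC(=O)C1=C(C)NC(=O)NC1c1ccsc1` gives 6%
- compound 3 `CC1=C(C(=O)OCc2ccccc2)C(c2ccsc2)NC(=O)N1` gives 25%

Compound 2 stands lowest of the three. Compound 1 sits higher, a number 26 percentage points lower from compound 1 to compound 2 (beyond the scatter); compound 3 sits higher too, a number 19 percentage points higher from compound 2 to compound 3 (beyond the scatter). Both steps are modest.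

Compound 4 `CCCC(=O)C1=C(C)NC(=O)NC1c1ccsc1` is not yet measured. Against compound 2 the difference is propyl in place of propoxy on a carbonyl carbon. Neither measured step bears on this place: the step from compound 1 to compound 2 concerns the thiophene attachment, the step from compound 2 to compound 3 the chain bound to oxygen, and neither removes the oxygen itself. Among the measured compounds shown here, with no step touching the carbonyl carbon, no change beyond the scatter is expected, a number 2 percentage points higher from compound 2 to compound 4 (within the scatter). Compound 4 is therefore estimated at 8%, within 0% to 25%.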

Compound 4, a percentage reported as inhibition, at one concentration (the size of the read-out at that concentration, not a potency): 1%
Compound 4: the middle estimate sits 7 percentage points above what was measured; the range from low to high includes it.
By their numbers in this assay, from the lowest: compounds 4 and 2 (each within the scatter of the next); then compounds 3 and 1 (each within the scatter of the next).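

Propyl in place of propoxy on a carbonyl carbon is the first change at this place, and in this assay it gives a number 5 percentage points lower from compound 2 to compound 4 (within the scatter). Removing the oxygen from the propoxycarbonyl group therefore leaves no change beyond the scatter, although compound 2 gives only 6%, so a further drop would be hard to detect. Nothing available explains this result.

From the compounds shown here alone, it remains open whether the same change would hold on the core of compound 1, which gives 32%. Also open, going by these compounds, is how an amine or a longer chain on this carbonyl carbon would read.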